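Extending the amide substituent of a weakly cytotoxic quinone

This account rests on a few compounds, and the source may have more. Where it says the series, first, only, none or still open, it means among the compounds named here.

Compound 1 `CN(C)C(=O)c1ccc(-c2cc(C3=CC(=O)C=CC3=O)no2)s1` carries a dimethylcarbamoyl group on the shared core. In a functional assay on A549 cells (Homo sapiens) for cytotoxicity, read by XTT assay, with a stated time of 72 h (a lower number here means a stronger inhibitor, a higher number a weaker inhibitor), compound 1 gives > 30000 nM, which is a limit of the assay and not a number. Two related compounds were also measured. Compound 2 `CCCN(C)C(=O)c1ccc(-c2cc(-c3cc(OC)ccc3OC)no2)s1` bears a methyl(propyl)carbamoyl group together with a dimethoxyphenyl group in place of the quinone. In this assay compound 2 gives > 30000 nM, again a limit. Compound 3 `COc1ccc(OC)c(-c2cc(-c3ccc(C(=O)NCC4CC4)s3)on2)c1` replaces the methyl(propyl)amino group by a (cyclopropylmethyl)amino group on the carbonyl carbon. In this assay compound 3 gives > 30000 nM, likewise a limit. Within the data shown here, the only step between measured neighbours, a step that the two limits leave unreadable from compound 2 to compound 3, therefore cannot be sized. Across the set, the limit of > 30000 nM in this assay, at which 3 of the 3 values shown sit, describes the whole of what has been measured.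

Compound 4 `CCCN(C)C(=O)c1ccc(-c2cc(C3=CC(=O)C=CC3=O)no2)s1` differs from compound 1 by ethyl in place of hydrogen on a saturated chain carbon bound to an amide-type nitrogen. Among the measured compounds shown here, no measured step bears directly on this change, and the one available step between compounds 2 and 3 is unreadable, so no direction or size beyond the scatter can be derived from the data. The step from compound 1 to compound 4 is expected to be a step that the limit leaves unreadable from compound 1 to compound 4. Compound 4 is estimated at 40000 nM, with a range from 15000 nM to 150000 nM, most probably reported as a limit again.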

Compound 4, half-maximal inhibitory concentration: > 30000 nM
Compound 4: a limit, no number (the forecaster's own chance of this, stated with the estimate: 85%); the middle value is on the limit's open side.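

Among these compounds, compound 1 and compound 4 both give limits of the assay and not numbers in this assay, and no step between them can be read. The whole set stands at one reading: the limit of > 30000 nM in this assay, at which 4 of the 4 values shown sit. The compounds shown leave open whether dimethylcarbamoyl to methyl(propyl)carbamoyl alters cytotoxicity at all, and how any of these compounds rank.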